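This account rests on a few compounds, and the source may have more. Where it says the series, first, only, none or still open, it means among the compounds named here.

Measured compounds in a functional assay on HeLa cells (Homo sapiens) for antiproliferative activity, read by MTT assay, with a stated time of 72 h; on this read-out higher numbers stand for weaker inhibition and lower numbers for stronger inhibition:
compound 1, `COc1cccc(N2C(=O)COc3ccc(-c4cnc(Cl)c(NS(=O)(=O)c5ccc(F)cc5)c4)cc32)c1`: > 40000 nM
compound 2, `O=C1COc2ccc(-c3ccc(O)cc3)cc2N1`: > 40000 nM
compound 3, `COc1ccc(N2C(=O)COc3ccc(-c4ccc(O)cc4)cc32)cc1`: 16400 nM

Compound 1 gives only a limit of this assay, > 40000 nM. Compound 2 likewise gives only a limit, > 40000 nM. For the measured compounds named here, compound 3 is the one compound with a number, 16400 nM. Going by the values given here, the single measured step, an at least 2.4-fold lower number from compound 2 to compound 3 (0.38 log units; beyond the scatter), puts 4-methoxyphenyl in place of hydrogen on an amide-type nitrogen in a ring; it does show that a substituent at that nitrogen can move the read-out, but it starts from hydrogen, whereas compound 1 already carries an aryl group there. Among the compounds with values here, no measured step exchanges one aryl group for another at that position.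

Compound 4, `O=C1COc2ccc(-c3cnc(Cl)c(NS(=O)(=O)c4ccc(F)cc4)c3)cc2N1c1ccc(Cl)cc1`, differs from compound 1 by 4-chlorophenyl in place of 3-methoxyphenyl on an amide-type nitrogen in a ring. Compound 1 stands at the limit of > 40000 nM in this assay, at which 2 of the 3 values shown sit, so there is no number to step from, only the limit. Within the data shown here, with no directly comparable step, no shift beyond the scatter is expected, and the expected step of a number no higher from compound 1 to compound 4 (the limit leaves the size open) is essentially flat. Compound 4 is therefore estimated at 40000 nM, in a range of 15000 nM to 100000 nM.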

Compound 4, half-maximal inhibitory concentration: > 40000 nM
Compound 4: a limit, no number; the forecaster's own chance of this, stated with the estimate: 65%; the middle value lies on the limit itself.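

Compound 1 and compound 4 both give only a limit in this assay, so no step between them can be read: the limit of > 40000 nM in this assay, at which 3 of the 4 values shown sit.

The compounds shown leave open how exchanging one aryl group for another on the amide-type nitrogen in a ring moves the read-out.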